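Swapping Chlorine for Fluorine on the Middle Ring

A few compounds are considered here, and "the series" means these few. Any claim that something is new, unique, unknown or untested is made for them only; others in the source may bear on it.

Of the compounds shown here, three sharing one core have been tested in a functional assay on CHO-K1 cells for antagonist activity at prostaglandin E2 receptor EP1 subtype (Homo sapiens), read by FLIPR; on this read-out lower numbers stand for stronger inhibition and higher numbers for weaker inhibition. Compound 1 `O=C(O)c1ccnn1Cc1cc(Br)ccc1OCc1ccccc1` reaches only a limit of the assay, < 2000 nM. Compound 2 `Cc1cc(C(=O)O)nn1Cc1cc(Cl)ccc1OCc1ccc(Cl)cc1Cl` gives 0.55 nM. Compound 3 `Cc1cc(C(=O)O)nn1Cc1cc(Cl)ccc1OCc1ccc(F)cc1F` gives 1.12 nM, the higher of the two numbers, since a 2.0-fold higher number from compound 2 to compound 3 (0.31 log units; beyond the scatter). Compound 4 `Cc1cc(C(=O)O)nn1Cc1cc(F)ccc1OCc1ccc(F)cc1F` differs from compound 3 in one place: fluoro in place of chloro on an aromatic carbon. Among the compounds with values here, no measured pair alters this position. Within the data shown here, the only measured change of a chlorine to a fluorine, a 2.0-fold higher number from compound 2 to compound 3 (0.31 log units; beyond the scatter), sits on another ring and was modest, so a small shift toward a weaker number, or none beyond the scatter, is expected here. For compound 4 the expected step is a 1.4-fold higher number from compound 3 to compound 4 (0.15 log units; within the scatter). Compound 4 is estimated at 1.6 nM, between 0.5 nM and 5 nM.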

Compound 4, inhibition constant: 7.94 nM
The estimate for compound 4 lay 5.0-fold (0.70 log units) below the measured number; the whole stated range lies below it.
By their numbers in this assay, from the lowest: compound 2; then compound 3; then compound 4.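

Changing chloro to fluoro on this aromatic carbon gives a 7.1-fold higher number from compound 3 to compound 4 (0.85 log units; beyond the scatter) in this assay. That is larger than the earlier change of chlorines to fluorines on the other ring, a 2.0-fold higher number from compound 2 to compound 3 (0.31 log units; beyond the scatter), so this single position on the shared core clearly affects the number. Nothing shown accounts for this step.

From the compounds shown here alone, only chloro and fluoro can be compared at this position on this core, so it remains open how a nitrile or a trifluoromethyl group there would read out.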